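Extending a pyrrolidine side chain by replacing it with azepane

The compounds below may be only part of what the source reports. "The series", "measured", "known", "first", "only" and "open" are said of these compounds alone.

Of the compounds shown here, three sharing one core have been measured in a functional assay on cells for antagonist activity at C-C chemokine receptor type 4 (Homo sapiens), read by fluorescence and calcium flux, with stated times of 2.5 s and 45 s; a lower number here means a stronger inhibitor, a higher number a weaker inhibitor. Compound 1 `Cc1nn([C@H](C)c2ccc(Cl)cc2Cl)c2nc(N3CC[C@H](N4CCC[C@H]4CCC(N)=O)[C@H](C)C3)cnc12` gives 37 nM, compound 2 `Cc1nn([C@H](C)c2ccc(Cl)cc2Cl)c2nc(N3CC[C@H](N4CCC[C@H]4C(=O)O)[C@H](C)C3)cnc12` gives 670 nM, and compound 3 `Cc1nn([C@H](C)c2ccc(Cl)cc2Cl)c2nc(N3CC[C@H](N4CCC[C@H]4CCC#N)[C@H](C)C3)cnc12` gives 41 nM. Compound 3 thus holds the second highest number of the three, lying within the scatter of compound 1 and far from compound 2, which shows a 16-fold lower number from compound 2 to compound 3 (1.21 log units; beyond the scatter).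

Compound 4 `Cc1nn([C@H](C)c2ccc(Cl)cc2Cl)c2nc(N3CC[C@H](N4CCCCCC4)[C@H](C)C3)cnc12` introduces (azepan-1-yl in place of 2-(2-cyanoethyl)pyrrolidin-1-yl on a saturated ring carbon). Among the measured compounds shown here, two measured steps bear on this change only indirectly. The step of a 1.1-fold higher number from compound 1 to compound 3 (0.04 log units; within the scatter) shows that the terminal group on the chain matters little, while an 18-fold higher number from compound 1 to compound 2 (1.26 log units; beyond the scatter) shows that cutting the chain down to a carboxy group costs a great deal. For the measured compounds named here, compound 4 removes the chain entirely and enlarges the ring, a combination no measured pair reproduces, so the expectation is uncertain but leans toward a weaker inhibitor. Compound 4 is therefore expected to give 150 nM, with a likely range from 40 nM to 600 nM. This corresponds to an expected 3.7-fold higher number from compound 3 to compound 4 (0.56 log units; beyond the scatter).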

Compound 4, half-maximal inhibitory concentration: 23 nM
Estimate against measurement, compound 4: 6.5-fold (0.81 log units) above, outside the stated range (below it).
By their numbers in this assay, from the lowest: compounds 4, 1 and 3 (each within the scatter of the next); then compound 2.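

In this assay, azepan-1-yl on this saturated ring carbon gives up the side chain without a measurable loss: a 1.8-fold lower number from compound 3 to compound 4 (0.25 log units; within the scatter) and a 1.6-fold lower number from compound 1 to compound 4 (0.21 log units; within the scatter) both lie within the scatter. The 2-(2-cyanoethyl)pyrrolidin-1-yl and 2-(2-carbamoylethyl)pyrrolidin-1-yl groups are thus not required at this position for numbers of this size, while 2-carboxypyrrolidin-1-yl stands well apart, with a 29-fold lower number from compound 2 to compound 4 (1.46 log units; beyond the scatter). Nothing available here explains these results.

Ring size and side chain change together in all of these steps, so it remains open how a plain pyrrolidin-1-yl or a piperidin-1-yl group would stand at this position. Also open, as far as these compounds go, is what a 2-cyanoethyl chain or a carboxylic acid would do when carried on the azepane ring itself.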